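From chloro to fluoro: compound 2 and compound 4

The compounds below may be only part of what the source reports. "The series", "measured", "known", "first", "only" and "open" are said of these compounds alone.

Values in an ADME assay on MT4 cells (Homo sapiens) for cytotoxicity, read by MTT assay; a higher number here means that more compound is tolerated, a lower number that less compound is tolerated:
compound 1 `CCc1c(Cc2c(F)cccc2Cl)nc(SCC(=O)c2ccc(F)cc2)[nH]c1=O`: > 57000 nM
compound 2 `CCc1c(Cc2c(F)cccc2Cl)nc(SCC(=O)c2ccc(OC)cc2)[nH]c1=O`: > 11000 nM
compound 3 `CCC(C)c1c(Cc2c(F)cccc2Cl)nc(SCC(=O)c2ccc(OC)cc2)[nH]c1=O`: 40000 nM

Compound 2 is known in this assay only as a limit, > 11000 nM. Compound 1 is likewise known only as a limit, > 57000 nM. Among the three, compound 3 alone has a number, 40000 nM.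

Compound 4 `CCc1c(Cc2c(F)cccc2F)nc(SCC(=O)c2ccc(OC)cc2)[nH]c1=O` carries a 2,6-difluorobenzyl group where compound 2 carries a 2-chloro-6-fluorobenzyl group: fluoro in place of chloro on an aromatic carbon. This is fluoro in place of chloro on an aromatic carbon.

Two measured steps start or end at compound 2. One is a step that the two limits leave unreadable from compound 1 to compound 2, and the other is a step that the limit leaves unreadable from compound 2 to compound 3. Neither has a readable size, and neither changes this halogen, so they give no measured guide to the new step. With so little to go on, no step beyond the usual scatter is expected, and the expected step is a step that the limit leaves unreadable from compound 2 to compound 4. The expected level rests on compound 3 at 40000 nM. A result reported only as a limit would be no surprise. For compound 4 the estimate is 30000 nM, with an expected range from 11000 nM to 80000 nM.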

Compound 4, half-maximal cytotoxic concentration: > 58000 nM
Compound 4 was reported as a limit; the forecaster's own chance of this, stated with the estimate: 55%; middle value at least 1.9-fold (0.28 log units) away from the limit.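

Compound 2 and compound 4 are both known in this assay only as limits, so no step can be read between them. The compounds shown leave open whether fluoro in place of chloro on an aromatic carbon changes the tolerated concentration at all, and by how much.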